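This account rests on a few compounds, and the source may have more. Where it says the series, first, only, none or still open, it means among the compounds named here.

Compound 1, `O=C(O)c1ccccc1-c1ccc(CCc2ncc(Cc3ccccc3F)[nH]2)cc1`: 9.5 nM
Compound 2, `N#Cc1ccccc1Cc1cnc(CCc2ccc(-c3ccccc3C(=O)O)cc2)[nH]1`: 642 nM
Compound 3, `COc1ccccc1Cc1cnc(CCc2ccc(-c3ccccc3C(=O)O)cc2)[nH]1`: 163 nM

These three compounds share one core and differ only in the substituent on the benzyl ring. In an in vitro functional assay on cells for agonist activity at Bombesin receptor subtype-3 (Mus musculus), read by luminescence and calcium flux (on this read-out lower numbers stand for an effect already at smaller amounts and higher numbers for an effect only at larger amounts of compound), compound 1 gives the lowest number of the three: compound 3 lies at a 17-fold higher number from compound 1 to compound 3 (1.23 log units; beyond the scatter) and compound 2 at a 68-fold higher number from compound 1 to compound 2 (1.83 log units; beyond the scatter), both beyond the scatter. Between them, the move from compound 2 to compound 3 is a 3.9-fold lower number from compound 2 to compound 3 (0.60 log units; beyond the scatter).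

Compound 4, `O=C(O)c1ccccc1-c1ccc(CCc2ncc(Cc3ccc(Cl)cc3)[nH]2)cc1`, has not yet been measured. Its difference from compound 1 is 4-chlorophenyl in place of 2-fluorophenyl on a saturated chain carbon bound to an aromatic carbon. Going by the values given here, no measured step covers this exact change: the two measured steps replace the fluoro with another group in the same place, whereas compound 4 moves the halogen to another place and exchanges fluoro for chloro. What the measured steps do show is that the benzyl ring is sensitive, since both replacements of the fluoro raised the number, once a lot and once very much.

For compound 4, a higher number than for compound 1 is therefore expected, probably a modest to large step, estimated as a 4.7-fold higher number from compound 1 to compound 4 (0.68 log units; beyond the scatter). The expected value for compound 4 is 45 nM, within a range of 8 nM to 300 nM.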

Compound 4, half-maximal effective concentration: 102 nM
Estimate against measurement, compound 4: 2.3-fold (0.36 log units) below; the range from low to high includes it.
By their numbers in this assay, from the lowest: compound 1; then compounds 4 and 3 (each within the scatter of the next); then compound 2.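

In this assay, the 2-fluorophenyl group of compound 1 now stands apart from a halogen-bearing ring as well, with an 11-fold higher number from compound 1 to compound 4 (1.03 log units; beyond the scatter), so among these compounds a halogen on the benzyl ring does not by itself keep the low number of compound 1. The 4-chlorophenyl group also joins the 2-methoxyphenyl group of compound 3 in one band, as a 1.6-fold lower number from compound 3 to compound 4 (0.20 log units; within the scatter) cannot be told apart from repeat scatter, whereas a 6.3-fold lower number from compound 2 to compound 4 (0.80 log units; beyond the scatter) clearly separates it from the 2-cyanophenyl group, which thus remains the least favourable of the replacements shown. Nothing measured here explains why the 2-fluorophenyl group stands apart from the other three.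

Compound 4 exchanges the halogen and moves it in one change, so these compounds leave open how much of its step belongs to chlorine in place of fluorine and how much to the new place on the ring. Also open, as far as these compounds go, is whether a benzyl ring with no substituent, or one carrying a hydroxyl, an amine or a trifluoromethyl group, would come close to compound 1.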